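Swapping Bromo for Trifluoromethyl on the Aniline Ring

A few compounds are considered here, and "the series" means these few. Any claim that something is new, unique, unknown or untested is made for them only; others in the source may bear on it.

Compound 2 `COc1cc2ncnc(Nc3ccc(Br)cc3)c2cc1OCCCCC(=O)Nc1ccc(S(N)(=O)=O)cc1` gives 23300 nM in a functional assay on NCI-H1975 cells (Homo sapiens) for antiproliferative activity, read by MTT assay, with a stated time of 72 h (a higher number here means a weaker inhibitor, a lower number a stronger inhibitor), the highest of the three numbers: compound 1 `COc1cc2ncnc(Nc3cccc(Br)c3)c2cc1OCCCCC(=O)Nc1ccc(S(N)(=O)=O)cc1` gives 11400 nM and compound 3 `COc1ccccc1Nc1ncnc2cc(OC)c(OCCCCC(=O)Nc3ccc(S(N)(=O)=O)cc3)cc12` gives 8030 nM. The steps of a 2.0-fold higher number from compound 1 to compound 2 (0.31 log units; beyond the scatter) and a 2.9-fold lower number from compound 2 to compound 3 (0.46 log units; beyond the scatter) are modest, while a 1.4-fold lower number from compound 1 to compound 3 (0.15 log units; within the scatter) stays within the scatter. Compound 4 `COc1cc2ncnc(Nc3ccc(C(F)(F)F)cc3)c2cc1OCCCCC(=O)Nc1ccc(S(N)(=O)=O)cc1` differs from compound 2 by trifluoromethyl in place of bromo on an aromatic carbon. For the measured compounds named here, no measured step exchanges one group for another at this place; the measured steps only move a group around the ring, and none exceeds a modest size. Compound 4 is therefore expected to show a step of roughly a 1.2-fold lower number from compound 2 to compound 4 (0.07 log units; within the scatter), not beyond the scatter. The estimate for compound 4 is 20000 nM, with a range from 8000 nM to 50000 nM.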

Compound 4, half-maximal inhibitory concentration: 12000 nM
Compound 4: middle estimate off by 1.7-fold (0.22 log units), on the high side; the range from low to high includes it.
By their numbers in this assay, from the lowest: compounds 3, 1, 4 and 2 (each within the scatter of the next, the first and the last beyond it).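

In this assay, for the compounds shown here, the first exchange of one group for another at this place, trifluoromethyl in place of bromo, gives a 1.9-fold lower number from compound 2 to compound 4 (0.29 log units; within the scatter), which stays within the scatter. Unlike compound 2, compound 4 is not separated from the other two compounds, with a 1.5-fold higher number from compound 3 to compound 4 (0.17 log units; within the scatter) and a 1.1-fold higher number from compound 1 to compound 4 (0.02 log units; within the scatter). No measurement shown here explains these results. As far as these compounds go, it remains open whether an amine, a carboxylic acid or a nitrile at this place would give a step beyond the scatter.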